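Removing the 2-acetylethenyl group from compound 3

This account rests on a few compounds, and the source may have more. Where it says the series, first, only, none or still open, it means among the compounds named here.

Values in an ADME assay on BJ cells (Homo sapiens) for cytotoxicity, with a stated time of 72 h; on this read-out lower numbers stand for an effect already at smaller amounts and higher numbers for an effect only at larger amounts of compound:
compound 1 `COc1ccc(/C=C/[C@@](C)(/C=C/c2ccc(O)c(/C=C/C#N)c2)CCC=C(C)C)cc1`: > 23700 nM, a limit
compound 2 `COc1ccc(/C=C/[C@@](C)(/C=C/c2ccc(O)c(/C=C/C(=O)OC(C)(C)C)c2)CCC=C(C)C)cc1`: > 36600 nM, a limit
compound 3 `COc1ccc(/C=C/[C@@](C)(/C=C/c2ccc(O)c(/C=C/C(C)=O)c2)CCC=C(C)C)cc1`: 12300 nM

Of these three, only compound 3 gives a true number, and the other two entries are limits. The next compound to be measured is compound 4 `COc1ccc(/C=C/[C@@](C)(/C=C/c2ccc(O)cc2)CCC=C(C)C)cc1`. The change is hydrogen in place of 2-acetylethenyl on an aromatic carbon, ortho to a hydroxy group (hydrogen in place of 2-acetylethenyl on an aromatic carbon).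

For the measured compounds named here, two measured steps bear on this, although both only exchange a group on the double-bonded chain carbon: an at least 2.9-fold lower number from compound 2 to compound 3 (0.47 log units; beyond the scatter) and an at least 1.9-fold lower number from compound 1 to compound 3 (0.28 log units; that floor lies within the scatter). Only the first of these clears the scatter, and both are floors rather than sizes. Going by the values given here, no measured step removes the whole 2-acetylethenyl group, so the size of the coming step is poorly constrained. Since compound 3 at 12300 nM alone gives a number, a modest move towards a higher number is expected in this assay. For compound 4 a limit may be reported instead of a number. The expected change is a 2.0-fold higher number from compound 3 to compound 4 (0.31 log units; beyond the scatter). The estimate for compound 4 is 25000 nM, with an expected range from 10000 nM to 60000 nM.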

Compound 4, half-maximal effective concentration: > 36600 nM
Compound 4 was reported as a limit (the forecaster's own chance of this, stated with the estimate: 50%); at least 1.4-fold (0.16 log units) between middle value and limit.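

In this assay, taking away the whole 2-acetylethenyl group gives an at least 2.9-fold higher number from compound 3 to compound 4 (0.47 log units; beyond the scatter), the first step shown that empties this position, ortho to a hydroxy group, instead of only exchanging the end of the chain carried there. Among the compounds shown, a measured number therefore appears only with 2-acetylethenyl in place, while the unsubstituted position gives no number, so the acetyl-bearing chain goes with the lower reading in this pair. Compound 4 stands as a limit, which makes the step a floor with its true size unknown: the limit of > 36600 nM in this assay, at which 2 of the 4 values shown sit.

The steps from compound 1 and from compound 2 to compound 4 cannot be read, as each joins two limits, so the 2-cyanoethenyl and 2-(tert-butoxycarbonyl)ethenyl groups cannot be ranked against hydrogen at this position. Also open, going by these compounds, is whether the number seen with compound 3 depends on the double bond of the chain or on its ketone carbonyl, and what an amine, a carboxylic acid or a longer chain at this position would give on this read-out.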